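Swapping thiophen-2-yl for 1-benzofuran-2-yl at the assay limit

The source may report more compounds than this note shows. Statements on the series, on what has been measured and on what is new or still open speak of the compounds shown alone.

In a functional assay on HCT-116 cells (Homo sapiens), read by MTT assay, with a stated time of 72 h (a higher number here means a weaker inhibitor, a lower number a stronger inhibitor), compound 1 `C#Cc1cn([C@@H]2O[C@H](CO)[C@@H](O)[C@H]2O)c2ncnc(OC)c12`, which has different groups on the shared core, gives a true number of 5140 nM. Compound 2 `CSc1ncnc2c1c(-c1cccs1)cn2[C@@H]1O[C@H](CO)[C@@H](O)[C@H]1O` reads > 20000 nM, which is a limit of the assay and not a number. Compound 3 `CNc1ncnc2c1c(-c1cccs1)cn2[C@@H]1O[C@H](CO)[C@@H](O)[C@H]1O` reads > 20000 nM, and this too is only a limit. The two share (the limit of > 20000 nM in this assay, at which 2 of the 3 values shown sit), so the starting point for the next step is not a number at all.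

Compound 4 `CNc1ncnc2c1c(-c1cc3ccccc3o1)cn2[C@@H]1O[C@H](CO)[C@@H](O)[C@H]1O` keeps the methylamino group of compound 3 and changes one group on an aromatic carbon, with 1-benzofuran-2-yl in place of thiophen-2-yl on an aromatic carbon.

Among the measured compounds shown here, the only measured step between two close relatives is a step that the two limits leave unreadable from compound 2 to compound 3. It concerns a different group at a different place and has no readable size, so it offers no size to carry over. With no measured guide, the expectation is that compound 4 stays near the limit of this assay, though a number somewhat lower remains possible. The expected change is a number no higher from compound 3 to compound 4 (the limit leaves the size open), and this is a rough estimate. For compound 4 the estimated value is 20000 nM, within an expected range of 7000 nM to 40000 nM.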

Compound 4, half-maximal inhibitory concentration: > 20000 nM
Compound 4 ended at the assay's limit (the forecaster's own chance of this, stated with the estimate: 65%); the middle value sits exactly at the limit.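

Compound 3 and compound 4 both sit at a limit of this assay, not at a true number, so no size can be read for the change from thiophen-2-yl to 1-benzofuran-2-yl: the limit of > 20000 nM in this assay, at which 3 of the 4 values shown sit.

The compounds shown leave open whether these two groups differ at all in this assay.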